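Methyl for Chloro on Two Related Carboxamide Cores

A few compounds are considered here, and "the series" means these few. Any claim that something is new, unique, unknown or untested is made for them only; others in the source may bear on it.

The account concerns four compounds tested in an assay on isolated protein for inhibition of Nicotinamide N-methyltransferase (Homo sapiens), read by luminescence, with a stated time of 20 min; on this read-out lower numbers stand for stronger inhibition and higher numbers for weaker inhibition. Compound 1 `CNc1cc(Cl)c(C(N)=O)cn1` gives 639 nM in this assay, and compound 2 `CNc1cc(C)c(C(N)=O)cn1` gives 282 nM. The two differ only by methyl in place of chloro on an aromatic carbon, and that single change produced a 2.3-fold lower number from compound 1 to compound 2 (0.36 log units; beyond the scatter).

Compound 3 `C[C@@H]1Cc2c(ncc(C(N)=O)c2Cl)N1` carries a different core; the difference between its core and that of compound 1 is not broken down here. In this assay compound 3 gives 48 nM, the lowest of the three numbers, with compound 2 nearest and compound 1 furthest from it.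

Compound 4 `Cc1c(C(N)=O)cnc2c1C[C@@H](C)N2` has not yet been measured. It is related to compound 3 by methyl in place of chloro on an aromatic carbon. Going by the values given here, this is the same kind of change as the one from compound 1 to compound 2, though the surroundings differ: in compound 3 the carbon sits on a ring that is part of a fused or bridged system of two rings, ortho to a fused ring and meta to a fused ring, whereas in compound 1 it is meta to a methylamino group. A step of about the same size is expected, a 2.2-fold lower number from compound 3 to compound 4 (0.34 log units; beyond the scatter), resting on the measured step of a 2.3-fold lower number from compound 1 to compound 2 (0.36 log units; beyond the scatter). For compound 4 the estimate in this assay is 22 nM, expected to fall between 10 nM and 50 nM.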

Compound 4, half-maximal inhibitory concentration: 43 nM
Beside the measured number, compound 4's estimate is 2.0-fold (0.29 log units) below it, within the range that was stated.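

On the core of compound 3, methyl in place of chloro on an aromatic carbon gave a 1.1-fold lower number from compound 3 to compound 4 (0.05 log units; within the scatter) in this assay, so the two compounds cannot be told apart on this read-out. Set beside the earlier step, this result does not separate the two cores: the same change on two cores in this assay, a 2.3-fold lower number (0.36 log units; beyond the scatter) from compound 1 to compound 2 and a 1.1-fold lower number (0.05 log units; within the scatter) from compound 3 to compound 4, 2.0-fold (0.31 log units) apart, within the scatter of two such steps. Going by these compounds alone, the change therefore gave no number beyond the scatter in the weaker direction on either core, but two pairs do not show that the step carries over at a fixed size, nor do they show that the core alters it, as only the step on the core of compound 1 lies beyond the scatter.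

The compounds shown leave open how other groups on that aromatic carbon, such as bromo, methoxy or nitrile, would read in this assay. Also open, as far as these compounds go, is whether the carbamoyl group could be replaced, for example by a carboxylic acid, and whether a longer chain could take the place of the methyl on the saturated ring.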